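A few compounds are considered here, and "the series" means these few. Any claim that something is new, unique, unknown or untested is made for them only; others in the source may bear on it.

Compound 1 `Cc1ccc(OCC(=O)N(Cc2cccs2)C2CCCCC2)cc1` gives 40000 nM in an assay on HEK293 cells for agonist activity at transient receptor potential cation channel subfamily M member 8 (Homo sapiens), read by fluorescence and calcium flux, with a stated time of 15 min; a lower number here means that less compound is needed, a higher number that more compound is needed for the effect. Compound 2 `Cc1ccc(OCC(=O)N(Cc2cccs2)c2cn[nH]c2)cc1` gives 1.4 nM in this assay.

Compound 2 holds the lower of the two numbers, far apart from compound 1: a 29000-fold lower number from compound 1 to compound 2 (4.46 log units; beyond the scatter). Compound 3 `Cc1ccc(OCC(=O)N(Cc2cccs2)c2cnccn2)cc1` differs from compound 2 in one place, (pyrazin-2-yl in place of 1H-pyrazol-4-yl on an amide-type nitrogen). Within the data shown here, only that one measured step bears on this change, and it shows how strongly the group on this nitrogen controls the result; it does not say how one aromatic ring compares with another. A moderate rise in this assay is expected, a 29-fold higher number from compound 2 to compound 3 (1.46 log units; beyond the scatter). Compound 3 is estimated at 40 nM, within 4 nM to 800 nM.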

Compound 3, half-maximal effective concentration: 1240 nM
Beside the measured number, compound 3's estimate is 31-fold (1.49 log units) below it, outside the stated range (above it).
By their numbers in this assay, from the lowest: compound 2; then compound 3; then compound 1.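

In this assay the aromatic ring on the amide-type nitrogen matters, not just its presence: pyrazin-2-yl in place of 1H-pyrazol-4-yl gives an 890-fold higher number from compound 2 to compound 3 (2.95 log units; beyond the scatter) and so loses much of what compound 2 gained. Pyrazin-2-yl in place of cyclohexyl still gives a 32-fold lower number from compound 1 to compound 3 (1.51 log units; beyond the scatter) on the same nitrogen. No outside evidence bears on why the two rings differ.

These compounds change ring size and hydrogen-bond donor count together, so they cannot separate the two. A 1-methyl-1H-pyrazol-4-yl or a plain phenyl group at this nitrogen would be the open comparison.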